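Chloro to Methyl on the Aryl Ring of Compound 1

This account rests on a few compounds, and the source may have more. Where it says the series, first, only, none or still open, it means among the compounds named here.

Compound 1 `O=C1C2=C(C(=O)c3ncccc31)C1(CS2)NC(=O)N(c2ccc(Cl)cc2)C1=O`: 10 nM
Compound 2 `O=C1NNC(=O)C2(CSC3=C2C(=O)c2ncccc2C3=O)N1`: 550 nM; 500 nM; 550 nM (3 entries)
Compound 3 `CCCCCc1ccc(N2C(=O)NC3(CSC4=C3C(=O)c3ncccc3C4=O)C2=O)cc1`: 190 nM

In a functional assay on MT4 cells (Homo sapiens) for antiproliferative activity, read by MTT assay, with a stated time of 96 h (a lower number here means a stronger inhibitor, a higher number a weaker inhibitor), compound 1 gives 10 nM, the lowest of the two single numbers in the set. Its nearest neighbour is compound 3, and the step of a 19-fold higher number from compound 1 to compound 3 (1.28 log units; beyond the scatter) is large, pentyl in place of chloro on an aromatic carbon. Compound 2, which carries no aryl group at all on the shared core, gives 550 nM; 500 nM; 550 nM (3 entries); its repeated entries the several entries of compound 2 in this assay, 550 nM; 500 nM; 550 nM (3 entries) lie close together, so that number is well settled.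

Compound 4 `Cc1ccc(N2C(=O)NC3(CSC4=C3C(=O)c3ncccc3C4=O)C2=O)cc1` differs from compound 1 by methyl in place of chloro on an aromatic carbon. Among the measured compounds shown here, only one measured step bears on this change: replacing chloro with pentyl in compound 3 raised the number markedly. Methyl is a far shorter alkyl than pentyl, and the values of compounds 1, 2 and 3 give no further guide, so the step from compound 1 to compound 4 is expected to go in the same direction but to be much smaller, at the edge of the usual scatter. On that basis compound 4 is estimated at 30 nM, with a range of 10 nM to 100 nM, a step of a 3.0-fold higher number from compound 1 to compound 4 (0.48 log units; beyond the scatter).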

Compound 4, half-maximal inhibitory concentration: 27 nM
Beside the measured number, compound 4's estimate is 1.1-fold (0.05 log units) above it; measured number inside the range.
By their numbers in this assay, from the lowest: compound 1; then compound 4; then compound 3.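

In this assay, methyl in place of chloro on the aromatic carbon para to a large group still gives a 2.7-fold higher number from compound 1 to compound 4 (0.43 log units; beyond the scatter), so the rise seen with pentyl at this place does not depend on a long chain: swapping one heavy atom for another is enough to move the number. Chain length also counts in its own right, since shortening pentyl to methyl at the same carbon gives a 7.0-fold lower number from compound 3 to compound 4 (0.85 log units; beyond the scatter), which is the larger of the two new steps; across compound 1, compound 4 and compound 3, the 4-chlorophenyl compound keeps the lowest number, and the two alkyl compounds order by length, a reading that rests on only two alkyl groups. Nothing measured in this set says why chloro gives a lower number than methyl at this place.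

As far as these compounds go, whether another halogen such as fluoro or bromo, or a methoxy group, would match or pass chloro at this carbon stays open. So does where ethyl or propyl would fall between compound 4 and compound 3, and whether an amine or a carboxylic acid could be tolerated here at all.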